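Methoxy on the aryl ether of a dihydrotriazine series

This account rests on a few compounds, and the source may have more. Where it says the series, first, only, none or still open, it means among the compounds named here.

Among the measured compounds shown here, three compounds share the spiro dihydrotriazine core: in an assay on isolated protein for inhibition of Dihydrofolate reductase (Homo sapiens), read by spectrophotometry, using NADPH, with stated times of 5 s and 6 min (on this read-out lower numbers stand for stronger inhibition and higher numbers for weaker inhibition), compound 1 `NC1=NC2(CCSCC2)N(OCCCOc2ccc(Cl)c(Cl)c2)C(N)=N1` gives "not determined" (no result reported) and compound 3 `CC(C)(C)c1ccc(OCCCON2C(N)=NC(N)=NC23CCSCC3)cc1` gives "not determined" (no result reported), so compound 2 `NC1=NC2(CCOCC2)N(OCCCOc2ccccc2)C(N)=N1` is the only member with a number in this assay, where compound 2 gives 86.1 nM. Compound 4 `COc1ccc(OCCCON2C(N)=NC(N)=NC23CCOCC3)cc1` is not yet measured. It differs from compound 2 by methoxy in place of hydrogen on an aromatic carbon. For the measured compounds named here, no measured pair shows this change, so the step is expected to be small, within or barely beyond the scatter, with no firm direction; the expected step is a 1.2-fold higher number from compound 2 to compound 4 (0.06 log units; within the scatter). Compound 4 is therefore estimated at 100 nM in this assay, with a range from 35 nM to 300 nM.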

Compound 4, half-maximal inhibitory concentration: 11.1 nM
Estimate against measurement, compound 4: 9.0-fold (0.95 log units) above; measured number below the stated range.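

In this assay, among the compounds shown here, the change from phenyl to 4-methoxyphenyl gives a 7.8-fold lower number from compound 2 to compound 4 (0.89 log units; beyond the scatter), the first measured step, and it lies beyond the scatter. The aromatic carbon para to a large group is therefore a place where one substituent clearly moves the number, and methoxy moves it downward. No evidence on the cause of this step is at hand. Open, on these data alone, is whether an amine or a longer ethoxy chain at this place would move the number in the same direction, and whether the methoxy step carries over to the core of compound 3.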